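This account rests on a few compounds, and the source may have more. Where it says the series, first, only, none or still open, it means among the compounds named here.

Working notes on a series of three measured compounds sharing one core. In a functional assay on DU-145 cells (Homo sapiens) for inhibition, read by trypan blue exclusion, with a stated time of 72 h (a lower number here means a stronger inhibitor, a higher number a weaker inhibitor), compound 1 `Cn1c(=O)c(S(=O)(=O)c2ccccc2)cc2cnc(Nc3cnc4[nH]ccc4c3)nc21` gives 1000 nM, compound 2 `Cn1c(=O)c(S(=O)(=O)c2ccc(Cl)cc2)cc2cnc(Nc3cnc4[nH]ccc4c3)nc21` gives 5000 nM and compound 3 `Cn1c(=O)c(S(=O)(=O)c2ccc(F)cc2)cc2cnc(Nc3cccc4[nH]ccc34)nc21` gives 750 nM. Compound 3 thus lies within the scatter of compound 1 and beyond the scatter of compound 2.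

The next compound is compound 4 `Cn1c(=O)c(S(=O)(=O)c2ccc(F)cc2)cc2cnc(Nc3cnc4[nH]ccc4c3)nc21`, which departs from compound 3 at a single place, on a nitrogen on an aromatic ring: a group of 9 heavy atoms (7 carbon, 2 nitrogen; one five-membered aromatic ring with 1 hetero atom, one six-membered aromatic ring with 1 hetero atom) in place of a group of 9 heavy atoms (8 carbon, 1 nitrogen; one five-membered aromatic ring with 1 hetero atom, one six-membered aromatic ring of carbon only), on a nitrogen on an aromatic ring. For the measured compounds named here, no measured step covers this exchange, so there is no direct precedent for its size. Going by the values given here, the only measured single-site step, a 5.0-fold higher number from compound 1 to compound 2 (0.70 log units; beyond the scatter), is modest and beyond the scatter, but it concerns chloro in place of hydrogen on an aromatic carbon, a different change at a different place. Compound 4 does share its entering group with compound 1 at 1000 nM and compound 2 at 5000 nM, and these two values frame the expectation, while the fluoro group stays as in compound 3. A small move towards a higher number is therefore expected in this assay, close to the edge of the scatter: a 2.0-fold higher number from compound 3 to compound 4 (0.30 log units; within the scatter). For compound 4 the estimate is 1500 nM, with an expected range from 500 nM to 5000 nM.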

Compound 4, half-maximal inhibitory concentration: 500 nM
Compound 4: the middle estimate sits 3.0-fold (0.48 log units) above what was measured, and the stated range covers the measured number.
By their numbers in this assay, from the lowest: compounds 4, 3 and 1 (each within the scatter of the next); then compound 2.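

In this assay, the exchange on a nitrogen on an aromatic ring, from 1H-indol-4-yl to the group with a six-membered aromatic ring with 1 hetero atom, gives a 1.5-fold lower number from compound 3 to compound 4 (0.18 log units; within the scatter), so at this place the change in ring atoms and the added hydrogen-bond acceptor leave the number inside the scatter. With that entering group held constant, the aromatic carbon now has three readings: a 10-fold lower number from compound 2 to compound 4 (1.00 log units; beyond the scatter) for fluoro in place of chloro and a 2.0-fold lower number from compound 1 to compound 4 (0.30 log units; within the scatter) for fluoro in place of hydrogen, so among these three substituents chloro alone stands apart, while fluoro and hydrogen cannot be separated. No measurement in hand bears on the reason for either result.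

The compounds shown pair 1H-indol-4-yl only with fluoro, so it remains open whether chloro would stand apart in the same way with that group at the nitrogen. Also open, on these data alone, is how this assay would read with a methoxy group, an amine or a carboxylic acid on that aromatic carbon, and whether any such group would give a step beyond the scatter towards a lower number.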